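Dimethylamino for methoxy on the shared core

The source may report more compounds than this note shows. Statements on the series, on what has been measured and on what is new or still open speak of the compounds shown alone.

Measured so far:
compound 1 `CN(C)c1ncnc2c1c(-c1ccsc1)cn2[C@@H]1O[C@H](CO)[C@@H](O)[C@H]1O`, a functional assay on HCT-116 cells (Homo sapiens), read by MTT assay, with a stated time of 72 h; on this read-out higher numbers stand for weaker inhibition and lower numbers for stronger inhibition: > 20000 nM
compound 2 `COc1ncnc2c1c(-c1cccs1)cn2[C@@H]1O[C@H](CO)[C@@H](O)[C@H]1O`, this assay: 440 nM

Compound 1 gives only a limit in this assay, (the limit of > 20000 nM in this assay, at which 1 of the 2 values shown sits). Among the compounds with values here, compound 2 gives the sole number, 440 nM. Compound 3 `CN(C)c1ncnc2c1c(-c1cccs1)cn2[C@@H]1O[C@H](CO)[C@@H](O)[C@H]1O` is not yet measured; it differs from compound 2 by dimethylamino in place of methoxy on an aromatic carbon. Compound 1 also carries a dimethylamino group and sits at the limit. The step from compound 2 to compound 3 is expected to go toward weaker inhibition, beyond the scatter, as an 11-fold higher number from compound 2 to compound 3 (1.06 log units; beyond the scatter). Compound 3 is expected at 5000 nM, within 1000 nM to 20000 nM.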

Compound 3, half-maximal inhibitory concentration: > 20000 nM
Compound 3 was reported as a limit; the forecaster's own chance of this, stated with the estimate: 35%; middle value at least 4.0-fold (0.60 log units) away from the limit.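

With the thiophen-2-yl group held constant, dimethylamino in place of methoxy on this aromatic carbon gives, in this assay, an at least 45-fold higher number from compound 2 to compound 3 (1.65 log units; beyond the scatter), which ties the loss of inhibition to this single change. As far as these compounds go, the value of compound 3, > 20000 nM, is a limit of the assay, so the full size of the step stays unknown. The step between thiophen-3-yl and thiophen-2-yl in the dimethylamino pair cannot be read: the limit of > 20000 nM in this assay, at which 2 of the 3 values shown sit.

From the compounds shown here alone, whether a methylamino or an ethoxy group on this carbon would keep the inhibition of compound 2, 440 nM, remains open.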